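The source may hold more compounds than are shown below. What is called first, only, known or untested is meant among the compounds shown, and "the series" means these compounds.

In a functional assay on HL-60 cells (Homo sapiens) for cytotoxicity, read by WST assay, with a stated time of 48 h (a lower number here means that less compound is needed, a higher number that more compound is needed for the effect), compound 1 (`Cc1ccccc1C[C@H]1C(=O)OC[C@@H]1Cc1ccccc1`) gives 57000 nM and compound 2 (`O=C1OC[C@H](Cc2ccccc2)[C@H]1Cc1ccc(O)cc1`) gives 88000 nM, so the two values lie within the scatter of each other. Compound 3 (`COCOc1ccc(C[C@H]2C(=O)OC[C@@H]2Cc2ccccc2)cc1`) has methoxymethyl in place of hydrogen on an oxygen on an aromatic ring, hydroxy to methoxymethoxy: methoxymethyl in place of hydrogen on an oxygen on an aromatic ring. For the measured compounds named here, only one measured step bears on this change, a 1.5-fold higher number from compound 1 to compound 2 (0.19 log units; within the scatter), and it introduced 4-hydroxyphenyl in place of 2-methylphenyl. Going by the values given here, no measured step tests the new group directly, so no step beyond the scatter is expected in this assay. The expected step is a 1.3-fold lower number from compound 2 to compound 3 (0.10 log units; within the scatter). Compound 3 is estimated at 70000 nM, with an expected range of 30000 nM to 160000 nM.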

Compound 3, half-maximal effective concentration: 71000 nM
Compound 3: middle estimate off by 1.0-fold (0.01 log units), on the low side; measured number inside the range.
By their numbers in this assay, from the lowest: compounds 1, 3 and 2 (each within the scatter of the next).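

With methoxymethyl in place of hydrogen on the oxygen on the aromatic ring, this assay shows a 1.2-fold lower number from compound 2 to compound 3 (0.09 log units; within the scatter) for this change. The hydrogen on this oxygen can therefore be replaced by methoxymethyl with no step beyond the scatter, a direct test that the earlier step from compound 1 to compound 2 did not give. Nothing measured bears on the reason for this result.

Still open, as far as these compounds go, is whether an amine, a carboxylic acid or a longer chain such as butoxy at this place would give a step beyond the scatter.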